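The source may hold more compounds than are shown below. What is called first, only, known or untested is meant among the compounds shown, and "the series" means these compounds.

Compound 1 `O=c1cc(Cn2ccnc2)c2ccc(OCc3cccc(Cl)c3)cc2o1` and compound 2 `O=c1cc(Cn2ccnc2)c2ccc(OCc3cc(F)cc(F)c3)cc2o1` share one core and differ only in the group on a saturated chain carbon bound to an oxygen on an aromatic ring. In an assay on V79MZh11B1 cells for inhibition of cytochrome P450 11B1, mitochondrial (Homo sapiens), read by HPLC, with a stated time of 25 min (on this read-out higher numbers stand for weaker inhibition and lower numbers for stronger inhibition), compound 1 gives 31 nM, and compound 2 gives 45 nM; the two numbers are not separable, since a 1.5-fold higher number from compound 1 to compound 2 (0.16 log units; within the scatter). Compound 3 `COc1cccc(COc2ccc3c(Cn4ccnc4)cc(=O)oc3c2)c1` carries 3-methoxyphenyl in place of 3,5-difluorophenyl on a saturated chain carbon bound to an oxygen on an aromatic ring. Within the data shown here, the only step that bears on this change is the one from compound 1 to compound 2, and it stayed within the scatter, so no step beyond the scatter is expected here, no change at the digits printed from compound 2 to compound 3 (within the scatter). Compound 3 is therefore estimated at 45 nM, between 15 nM and 140 nM.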

Compound 3, half-maximal inhibitory concentration: 48 nM
Compound 3: middle estimate off by 1.1-fold (0.03 log units), on the low side; the measured number falls inside the stated range.
By their numbers in this assay, from the lowest: compounds 1, 2 and 3 (each within the scatter of the next).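

Read in this assay, the 3-methoxyphenyl group matches both earlier groups: 3,5-difluorophenyl (a 1.1-fold higher number from compound 2 to compound 3 (0.03 log units; within the scatter)) and, with methoxy in place of chloro on an aromatic carbon, 3-chlorophenyl (a 1.5-fold higher number from compound 1 to compound 3 (0.19 log units; within the scatter)). At this position, then, a group with a hydrogen-bond acceptor reads no differently from the two halogen-bearing groups, so all three compounds stay within the scatter. Nothing available explains why these groups read alike. As far as these compounds go, what an amine or a carboxylic acid on this ring would do remains open. So does the effect of a longer chain in place of the benzyl group.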